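The source may hold more compounds than are shown below. What is called first, only, known or untested is meant among the compounds shown, and "the series" means these compounds.

Compound 1 `Fc1cc(Cl)ccc1-c1ccc(Cn2nnc3ccccc32)cn1` is the starting point. In an ADME assay on microsomes from liver (Homo sapiens) for metabolic stability, tested at 2.5 uM (a higher number here means faster removal of the compound, a lower number slower removal), compound 1 gives 0.01 mL/min/g, the lowest of the three numbers available. Compound 2 `Clc1ccc(-c2ccc(Cn3nnc4ccccc43)cn2)cc1` gives 0.2 mL/min/g in this assay, and compound 3 `Fc1cc(Cl)ccc1-c1ccc(Cn2nnc3c(F)cccc32)cn1` gives 0.1 mL/min/g. Both single changes away from compound 1 raise the number: a 20-fold higher number from compound 1 to compound 2 (1.30 log units; beyond the scatter), and a 10-fold higher number from compound 1 to compound 3 (1.00 log units; beyond the scatter).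

Compound 4 `Fc1ccc2nnn(Cc3ccc(-c4ccc(Cl)cc4F)nc3)c2c1` has not yet been measured. It differs from compound 1 by fluoro in place of hydrogen on an aromatic carbon. Among the compounds with values here, the step that bears most directly on it is the one to compound 3, where the same kind of change, fluoro in place of hydrogen on an aromatic carbon, gave a modest rise. The step to compound 2, hydrogen in place of fluoro on an aromatic carbon, also raised the number, so neither change among these compounds lowered it. A modest rise beyond the scatter is therefore expected, a 5.0-fold higher number from compound 1 to compound 4 (0.70 log units; beyond the scatter). Compound 4 is estimated at 0.05 mL/min/g, with a range from 0.015 mL/min/g to 0.2 mL/min/g.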

Compound 4, intrinsic clearance in a liver preparation (reported as CLH), per the amount of preparation that the assay uses: 0.1 mL/min/g
Compound 4: middle estimate off by 2.0-fold (0.30 log units), on the low side, within the range that was stated.
By their numbers in this assay, from the lowest: compound 1; then compounds 3, 4 and 2 (each within the scatter of the next).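

In this assay, fluoro in place of hydrogen on this aromatic carbon, meta to a fused ring and para to a fused ring, gives a 10-fold higher number from compound 1 to compound 4 (1.00 log units; beyond the scatter), so a second ring position also responds to this small change. Compound 3, with its fluoro on a different aromatic carbon, gives 0.1 mL/min/g and compound 4 gives 0.1 mL/min/g, which places the two within the scatter of each other, so these two compounds show no difference linked to where the fluoro sits. No supporting measurement is available to explain the rise seen with fluoro.

The compounds shown leave open whether a chloro, a methoxy or an amine at this position would behave like fluoro. They also leave open what two fluoro groups on this ring would do together.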